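Thiol analogue of compound 2 in the whole-organism assay

A few compounds are considered here, and "the series" means these few. Any claim that something is new, unique, unknown or untested is made for them only; others in the source may bear on it.

The series is followed in a functional assay for inhibition, with Homo sapiens as the target; a lower number here means a stronger inhibitor, a higher number a weaker inhibitor. Compound 1, `CCCc1nc(C)c2c(CC)nnc(SC)n12`, carries a methylthio group and an ethyl chain on the shared core. In this assay compound 1 reaches only the limit, > 48000 nM, and gives no number. Compound 2, `CCCc1nc(C)c2c(C(C)C)nnc(S)n12`, carries a free thiol and an isopropyl chain. In this assay compound 2 likewise stops at the limit, > 48000 nM, and gives no number. Within the data shown here, compound 2 thus stands at the edge of what the assay reports; both values so far sit at the limit of > 48000 nM in this assay, at which 2 of the 2 values shown sit, and no measured pair yields a step whose size could be read.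

Compound 3, `CCCc1nc(C)c2c(CC)nnc(S)n12`, is the thiol with an ethyl chain. It differs from compound 2 by hydrogen in place of methyl on a saturated chain carbon bound to an aromatic carbon and a saturated chain carbon. With both measured neighbours at the limit, no step beyond the scatter is expected in this assay, in either direction. The expected step is a step that the limit leaves unreadable from compound 2 to compound 3. Compound 3 is estimated at 60000 nM, with a range from 20000 nM to 200000 nM, most likely returned again only as a limit.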

Compound 3, half-maximal inhibitory concentration: > 48000 nM
Compound 3: no number, only a limit; the forecaster's own chance of this, stated with the estimate: 85%; the middle value does not contradict the limit.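

Compound 3 gives only a limit in this assay, > 48000 nM. No step to compound 3 can be read from compound 1 or compound 2, as all three compounds stand at the same limit: the limit of > 48000 nM in this assay, at which 3 of the 3 values shown sit.

The compounds shown leave open whether isopropyl to ethyl, or hydrogen in place of methyl on a sulfur, changes inhibition at all.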